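A pyrimidine amide replaces the methoxyphenyl on the shared core

The compounds below may be only part of what the source reports. "The series", "measured", "known", "first", "only" and "open" are said of these compounds alone.

Compound 1 `COc1cccc(C(=O)Nc2ccc(Cl)cc2CN2C(=O)c3ccccc3C2=O)c1` carries a 3-methoxyphenyl on the carbonyl carbon of its amide. In an assay on CHO cells for positive allosteric modulation of metabotropic glutamate receptor 5 (Rattus norvegicus), read by FLIPR (on this read-out higher numbers stand for an effect only at larger amounts of compound and lower numbers for an effect already at smaller amounts), compound 1 gives < 1000 nM, which is a limit of the assay and not a number. Compound 2 `O=C(Nc1ccc(Cl)cc1CN1C(=O)c2ccccc2C1=O)c1ccccc1` gives < 1000 nM in this assay, again only a limit. Compound 3 `O=C(Nc1ccc(Cl)cc1CN1C(=O)c2ccccc2C1=O)c1ccccc1C(F)(F)F` gives < 1000 nM in this assay, also a limit. Because (the limit of < 1000 nM in this assay, at which 3 of the 3 values shown sit), the step that the two limits leave unreadable from compound 1 to compound 2 cannot be sized, nor can a step that the two limits leave unreadable from compound 1 to compound 3 or a step that the two limits leave unreadable from compound 2 to compound 3. Compound 4 `O=C(Nc1ccc(Cl)cc1CN1C(=O)c2ccccc2C1=O)c1ncccn1` differs from compound 1 by pyrimidin-2-yl in place of 3-methoxyphenyl on a carbonyl carbon. No readable step bears on this change, so neither direction nor size of the step in this assay can be drawn from the three limits beyond their common ceiling. Compound 4 is therefore expected to give 500 nM in this assay, within a range from 100 nM to 3000 nM, an estimated step that the limit leaves unreadable from compound 1 to compound 4.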

Compound 4, half-maximal effective concentration: < 1000 nM
Compound 4 gave a limit, no number; the forecaster's own chance of this, stated with the estimate: 55%; the middle value lies beyond the limit too.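

The steps from compound 1, compound 2 and compound 3 to compound 4 cannot be read in this assay because all four compounds share one limit: the limit of < 1000 nM in this assay, at which 4 of the 4 values shown sit. As far as these compounds go, how far their effects actually differ, and whether pyrimidin-2-yl changes the effect at all, remains open.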